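The source may hold more compounds than are shown below. What is called first, only, known or untested is meant among the compounds shown, and "the series" means these compounds.

Measured compounds:
- compound 1, `CCc1nc2ccccc2n1CCCCOc1ccc(C)c(C)c1`: 14 uM
- compound 2, `CCc1nc2ccncc2n1CCCCOc1ccccc1`: "not determined" (no result reported)

Compound 1 was tested in an ADME assay on Vero cells (Chlorocebus sabaeus) for cytotoxicity, read by luminescence, with a stated time of 2 days (a higher number here means that more compound is tolerated, a lower number that less compound is tolerated), where compound 1 gives 14 uM. For compound 2 the outcome in this assay is "not determined" (no result reported), so no number is available for it. Going by the values given here, compound 1 therefore stands alone as the only compound with a number here, and nothing about a step between measured compounds can be drawn from this pair.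

Compound 3, `CCc1nc2ccccc2n1CCCCOC`, has not been measured yet. It differs from compound 1 in one place: methyl in place of 3,4-dimethylphenyl on an oxygen on a saturated carbon. The ring that is lost is large and the group that takes its place is a single carbon, so the compound becomes much smaller while the shared core and the chain stay as they are.

Without a measured step to lean on, the expectation rests only on the size of the change. The step from compound 1 to compound 3 is expected to be a 2.9-fold higher number from compound 1 to compound 3 (0.46 log units; beyond the scatter), a moderate move toward more compound being tolerated, somewhat beyond the usual scatter. For compound 3 the expected value in this assay is 40 uM, with a range from 12 uM to 130 uM.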

Compound 3, half-maximal toxic concentration: > 50 uM
Compound 3: only a limit was reported (the forecaster's own chance of this, stated with the estimate: 30%); middle value at least 1.2-fold (0.09 log units) from the limit.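

In this assay, going by these compounds alone, methyl in place of 3,4-dimethylphenyl on an oxygen on a saturated carbon gives an at least 3.5-fold higher number from compound 1 to compound 3 (0.55 log units; beyond the scatter) and this is the first readable step in the set, showing that the group at this end of the molecule makes a difference to how much compound the cells tolerate. For compound 3 the result is a limit, > 50 uM and not a number, so the step has a floor but no known top. As far as these compounds go, how far the change really reaches stays unknown, because compound 3 sits at that limit: the limit of > 50 uM in this assay, at which 1 of the 3 values shown sits.

This single step removes an aromatic ring and also shrinks the group from eight heavy atoms to one, so the compounds shown cannot separate the loss of the ring from the loss of size. From the compounds shown here alone, it also remains open whether a saturated cyclohexyl ring, a longer chain such as butyl, or an amine on the same chain would stay close to compound 1 or move toward compound 3 in this assay.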